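Swapping Selenium for Sulfur on the Shared Core

This account rests on a few compounds, and the source may have more. Where it says the series, first, only, none or still open, it means among the compounds named here.

In a functional assay on HT-29 cells (Homo sapiens) for cytotoxicity, read by MTT assay, with a stated time of 72 h (on this read-out higher numbers stand for lower toxicity in this test and lower numbers for higher toxicity in this test), compound 3 `C[Se]/C(=N\C(=O)c1cnc2ccccc2c1)NC(=O)c1cnc2ccccc2c1` gives only a limit of the assay, > 100000 nM. Compound 1 `CS/C(=N\C(=O)c1ccno1)NC(=O)c1ccno1` likewise reaches only a limit, > 100000 nM. Compound 2 `C[Se]/C(=N\C(=O)c1ccno1)NC(=O)c1ccno1` also stops at a limit, > 100000 nM. All three sit at the limit of > 100000 nM in this assay, at which 3 of the 3 values shown sit, so no numbered toxicity is known for any of them. Compound 4 `CS/C(=N\C(=O)c1cnc2ccccc2c1)NC(=O)c1cnc2ccccc2c1` carries a group of 2 heavy atoms (1 carbon, 1 sulfur; no ring) in place of a group of 2 heavy atoms (1 carbon, 1 selenium; no ring), on a carbon with a double bond to nitrogen. Among the measured compounds shown here, the one comparable step, a step that the two limits leave unreadable from compound 1 to compound 2, cannot be sized, as both of its ends are limits. No measured step therefore bears on this change in a readable way, and nothing shown gives ground to expect compound 4 to leave the limit. Compound 4 is expected at roughly 100000 nM, between 50000 nM and 300000 nM. The step of a number no higher from compound 3 to compound 4 (the limit leaves the size open) is expected to be none beyond the scatter.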

Compound 4, concentration lethal to 50% of the cells: > 100000 nM
Compound 4 gave a limit, no number; the forecaster's own chance of this, stated with the estimate: 85%; the middle value lies on the limit itself.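

Compound 3 and compound 4 each give only a limit in this assay, so no step can be read between them. Left open is whether sulfur or selenium on the shared core changes toxicity at all: the limit of > 100000 nM in this assay, at which 4 of the 4 values shown sit.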